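The source may report more compounds than this note shows. Statements on the series, on what has been measured and on what is new or still open speak of the compounds shown alone.

In a physicochemical assay for solubility, using the shake flask method, in simulated intestinal fluid, measured as kinetic solubility, with a stated time of 2 h, at 25 degrees C, at pH 6.5 (on this read-out higher numbers stand for higher solubility and lower numbers for lower solubility), compound 3 `Cc1nc(C(=O)O)c(N)c2c1C(=O)N(Cc1ccccc1)C2=O` gives 177000 nM as the only actual number shown. Compound 1 `CCOC(=O)c1nc(C)c2c(c1N)C(=O)N(Cc1ccccc1)C2=O` stands at < 5000 nM as a limit of the assay. Compound 2 `Cc1nc(C#N)c(N)c2c1C(=O)N(Cc1ccccc1)C2=O` stands at < 5000 nM as a limit too. The step to compound 4 `COC(=O)c1nc(C)c2c(c1N)C(=O)N(Cc1ccccc1)C2=O` is methyl in place of hydrogen on an oxygen next to a carbonyl group and reads as methyl in place of hydrogen on an oxygen next to a carbonyl group, or carboxy to methoxycarbonyl. Going by the values given here, the closest precedent is an at least 35-fold higher number from compound 1 to compound 3 (1.54 log units; beyond the scatter) and it runs the opposite way, while an at least 35-fold higher number from compound 2 to compound 3 (1.54 log units; beyond the scatter) is of similar size. A large fall is therefore expected in this assay with an estimated 51-fold lower number from compound 3 to compound 4 (1.70 log units; beyond the scatter) as its size. In this assay compound 4 is estimated at 3500 nM with an expected range from 1000 nM to 12000 nM and may be expected only as a limit of the assay.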

Compound 4, solubility: 7400 nM
Compound 4: the middle estimate sits 2.1-fold (0.33 log units) below what was measured, and the stated range covers the measured number.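

In this assay, methyl on the oxygen of the carboxy group of compound 3 gives a large fall (a 24-fold lower number from compound 3 to compound 4 (1.38 log units; beyond the scatter)), and the methyl ester still reads as an actual number. Against the two compounds held at a limit, only floors can be given (an at least 1.4-fold higher number from compound 1 to compound 4 (0.17 log units; that floor lies within the scatter); an at least 1.4-fold higher number from compound 2 to compound 4 (0.17 log units; that floor lies within the scatter)), and both floors lie within the scatter. Compound 4 therefore cannot be placed firmly against compound 1 or compound 2 because of where they sit: the limit of < 5000 nM in this assay, at which 2 of the 4 values shown sit. The compounds shown leave open how an amide or an amine would read on this aromatic carbon, and how a longer chain would read on this oxygen.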